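Compound 4: Trading the Hydroxyl Chain for a Methoxy Chain

The source may hold more compounds than are shown below. What is called first, only, known or untested is meant among the compounds shown, and "the series" means these compounds.

Compound 1 `Cc1ccc(C(=O)C2=C(O)C(=O)N(CC(C)O)C2c2ccc(C(C)C)cc2)cc1` was tested in an assay on isolated protein for inhibition of annexin A2/S100-A10 (Homo sapiens), with a stated time of 5 min, tested at 50 uM (on this read-out higher numbers stand for more inhibition at the one concentration tested (going by the name of the read-out) and lower numbers for less inhibition), where compound 1 gives 101%. Among the three measured compounds it stands second highest. Compound 2 `Cc1ccc(C(=O)C2=C(O)C(=O)N(CC(C)O)C2c2cccc(C(C)C)c2)cc1` gives 100%, and the step of a number 1 percentage points lower from compound 1 to compound 2 (within the scatter) lies within the scatter. Among the compounds with values here, compound 3 `Cc1ccc(C(=O)C2=C(O)C(=O)N(CC(C)O)C2c2ccc(C(C)(C)C)cc2)cc1` gives 123%; the step of a number 22 percentage points higher from compound 1 to compound 3 (beyond the scatter) is the one change that moved the read-out beyond the scatter, and the step of a number 23 percentage points higher from compound 2 to compound 3 (beyond the scatter) matches it.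

Compound 4 `COCCCN1C(=O)C(O)=C(C(=O)c2ccc(C)cc2)C1c1ccc(C(C)C)cc1` differs from compound 1 at the chain carried by the ring nitrogen: 2-methoxyethyl in place of 1-hydroxyethyl on a saturated chain carbon bound to an amide-type nitrogen in a ring. Within the data shown here, none of the measured steps touches this part of the molecule; all three exchange the substituted phenyl on a saturated ring carbon, and only the step to compound 3 moved the read-out beyond the scatter. Among the measured compounds shown here, with no measured step bearing on the changed place, compound 4 is expected to behave much like compound 1, with a step of a number 6 percentage points lower from compound 1 to compound 4 (within the scatter) that is expected to stay within the scatter. The estimate for compound 4 is therefore 95%, with a range from 70% to 115%.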

Compound 4, a percentage reported as inhibition, at one concentration (the size of the read-out at that concentration, not a potency): 111%
For compound 4 the middle estimate is 16 percentage points below the measured one; measured number inside the range.
By their numbers in this assay, from the lowest: compounds 2, 1 and 4 (each within the scatter of the next, the first and the last beyond it); then compound 3.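

In this assay, within the data shown here, compound 4 gives the first reading on a change at the chain carried by the ring nitrogen: the step, a number 10 percentage points higher from compound 1 to compound 4 (within the scatter), replaces 1-hydroxyethyl with 2-methoxyethyl on a saturated chain carbon bound to an amide-type nitrogen in a ring. The leaving chain has 1 hydrogen-bond donor and the entering chain has 0, so for this pair, at the one concentration tested, the read-out stays within the scatter without that donor. Nothing available accounts for this outcome or shows how the chain relates to the read-out.

Among these compounds, the single step alters the heavy-atom count and the donor count together, so the contribution of each remains open, and a single pair cannot show whether the number would be higher, lower or level with other groups at this position, such as a terminal amine, a carboxylic acid or a longer chain. From the compounds shown here alone, it also remains open whether the 2-methoxyethyl chain would give a similar read-out alongside the 4-(tert-butyl)phenyl group of compound 3.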